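Paw edema in the rat: removing the chloro substituent

A few compounds are considered here, and "the series" means these few. Any claim that something is new, unique, unknown or untested is made for them only; others in the source may bear on it.

Measured compounds:
compound 1, `CCOC(=O)c1c(-c2ccccc2OC)n(-c2ccc(C(=O)NNC(=O)CO[N+](=O)[O-])cc2)[nH]c1=O`, 31%
compound 2, `CCOC(=O)c1c(-c2ccc(Cl)cc2)n(-c2ccc(C(=O)NNC(=O)CO[N+](=O)[O-])cc2)[nH]c1=O`, 3.2%

Compound 2, `CCOC(=O)c1c(-c2ccc(Cl)cc2)n(-c2ccc(C(=O)NNC(=O)CO[N+](=O)[O-])cc2)[nH]c1=O`, gives the lower of the two numbers recorded in a functional assay on the whole organism (strain Wistar) for inhibition, with Rattus norvegicus as the target, read by paw edema, with a stated time of 1 h, at a dose of 6 mg/kg by the oral route; on this read-out lower numbers stand for less inhibition and higher numbers for more inhibition at the one dose given (going by the name of the read-out); compound 2 gives 3.2%. Among the measured compounds shown here, its only measured neighbour is compound 1, which in this assay gives 31%, and the one step recorded, a number 27.8 percentage points lower from compound 1 to compound 2 (beyond the scatter), separates them.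

Compound 3, `CCOC(=O)c1c(-c2ccccc2)n(-c2ccc(C(=O)NNC(=O)CO[N+](=O)[O-])cc2)[nH]c1=O`, is the next compound. Relative to compound 2 the change is hydrogen in place of chloro on an aromatic carbon. For the measured compounds named here, no measured step of this kind is available; the step from compound 1 to compound 2 concerns a different exchange, 4-chlorophenyl in place of 2-methoxyphenyl on an aromatic carbon, and so bears on compound 3 only in showing that this part of the molecule can move the read-out by a modest amount. With nothing else to lean on, the expectation for compound 3 is a value near that of compound 2, with some allowance for an upward shift; the estimated step is a number 8.8 percentage points higher from compound 2 to compound 3 (within the scatter). Compound 3 is therefore estimated at 12%, expected to lie between 0% and 32%.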

Compound 3, a percentage reported as inhibition, in the whole organism at one dose (the size of the read-out at that dose, not a potency): 54%
The estimate for compound 3 lay 42 percentage points below the measured number; measured number outside the range, above it.
By their numbers in this assay, from the lowest: compound 2; then compound 1; then compound 3.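

With the plain phenyl compound in hand, this assay has a reference point for this ring, and both substituents fall short of it: hydrogen in place of chloro, para to a large group, gives a number 50.8 percentage points higher from compound 2 to compound 3 (beyond the scatter), and hydrogen in place of methoxy gives a number 23 percentage points higher from compound 1 to compound 3 (beyond the scatter). The earlier pair showed only that 4-chlorophenyl and 2-methoxyphenyl differ, and could not say whether either group helped or cost anything at the one dose given. Compound 3 shows that, among these three compounds, an unsubstituted ring gives the most inhibition, that the chloro costs far more than the methoxy, and that no data shown here offer a reason for this.

The names 4-chlorophenyl and 2-methoxyphenyl put the two groups on different carbons of the ring, so the compounds shown leave open whether the group itself or its place sets the gap between them. From the compounds shown here alone, how an amine or a carboxylic acid on the carbon that held the chloro would read also stays open, as does whether this order holds at another dose or time.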